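The compounds below may be only part of what the source reports. "The series", "measured", "known", "first", "only" and "open" are said of these compounds alone.

Working notes on the series. The measure throughout is a functional assay on the whole organism (strain albino) for inhibition, with Rattus norvegicus as the target, read by paw edema, with stated times of 30 min and 1 h, at a dose of 25 mg/kg by the intraperitoneal route; a higher number here means more inhibition at the dose given (going by the name of the read-out), a lower number less inhibition. Compound 1 `C=C(C)C(=O)c1ccc(OC)cc1OC` gives 23.7% in this assay. Compound 2 `CCOC(=O)c1nn(-c2ccccc2)c(-c2ccc(OC)cc2OC)c1-c1ccccc1` gives 17.7% in this assay, and that number sits within the usual scatter of the reading for compound 1, so the two compounds cannot be told apart on these figures. Among the compounds with values here, no step between measured compounds differing in a single place is available, so nothing tells how a change on the five-membered ring moves the reading.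

Compound 3 `CCOC(=O)c1nn(-c2ccccc2)c(-c2ccc(OC)cc2OC)c1C` is not yet measured. It differs from compound 2 as follows: methyl in place of phenyl on an aromatic carbon. Within the data shown here, with no comparable step in hand, the expectation for compound 3 is a change of no size beyond the scatter, in either direction, that is a step of a number 0.3 percentage points higher from compound 2 to compound 3 (within the scatter). Compound 3 is therefore estimated at 18% in this assay, with a range from 5% to 32%.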

Compound 3, a percentage reported as inhibition, in the whole organism at one dose (the size of the read-out at that dose, not a potency): 4.9%
Beside the measured number, compound 3's estimate is 13.1 percentage points above it; the measured number lies below the stated range.
By their numbers in this assay, from the lowest: compound 3; then compounds 2 and 1 (each within the scatter of the next).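

Within the data shown here, this is the first step at this position: on the aromatic carbon of the five-membered aromatic ring with 2 nitrogen, methyl in place of phenyl gives a number 12.8 percentage points lower from compound 2 to compound 3 (beyond the scatter) in this assay. The group on this carbon therefore moves the reading, and by more than the scatter, with the phenyl of compound 2 keeping more inhibition than the methyl of compound 3. The step is modest and rests on a single pair at a single dose, and no measurement at hand offers an explanation for it.

On these data alone, how an ethyl or a benzyl group on this carbon would read remains open. Also open, as far as these compounds go, is whether the same step would hold with a carboxylic acid in place of the ethoxycarbonyl group.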